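Exchanging 3-nitrophenyl for 2,4-dihydroxyphenyl in the series

A few compounds are considered here, and "the series" means these few. Any claim that something is new, unique, unknown or untested is made for them only; others in the source may bear on it.

In a functional assay on MCF7 cells (Homo sapiens) for antiproliferative activity, read by MTT assay, with a stated time of 72 h (on this read-out higher numbers stand for weaker inhibition and lower numbers for stronger inhibition), compound 1 `O=C(N/N=C/c1ccccc1)Nc1ccc(Oc2ccnc3[nH]ccc23)c(F)c1` gives 2380 nM and compound 3 `COc1ccc(/C=N/NC(=O)Nc2ccc(Oc3ccnc4[nH]ccc34)c(F)c2)cc1` gives 5750 nM. Going by the values given here, the only measured step is a 2.4-fold higher number from compound 1 to compound 3 (0.38 log units; beyond the scatter), with methoxy in place of hydrogen on an aromatic carbon. Compound 2 `O=C(N/N=C/c1cccc([N+](=O)[O-])c1)Nc1ccc(Oc2ccnc3[nH]ccc23)c(F)c1` is reported as "not active" (no number reported), with no number attached. Among the compounds with values here, it therefore has no numeric position, and no step away from it can be sized.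

Compound 4 `O=C(N/N=C/c1ccc(O)cc1O)Nc1ccc(Oc2ccnc3[nH]ccc23)c(F)c1` is still to be measured. Its difference from compound 2 is 2,4-dihydroxyphenyl in place of 3-nitrophenyl on a carbon with a double bond to nitrogen; in words, 2,4-dihydroxyphenyl in place of 3-nitrophenyl on a carbon with a double bond to nitrogen. Within the data shown here, no measured step covers this exchange. The step of a 2.4-fold higher number from compound 1 to compound 3 (0.38 log units; beyond the scatter) bears on it only loosely, as a guide to how far a change on this aromatic ring has moved the read-out. The expected direction from compound 2 is towards a measurable number in this assay, close to the values of compound 1 at 2380 nM and compound 3 at 5750 nM, although a second result without a number remains possible. For compound 4 the estimated value is 4000 nM, with an expected range of 1200 nM to 15000 nM.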

Compound 4, half-maximal inhibitory concentration: 48000 nM
Estimate against measurement, compound 4: 12-fold (1.08 log units) below; the whole stated range lies below it.
By their numbers in this assay, from the lowest: compound 1; then compound 3; then compound 4.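

In this assay the position on a carbon with a double bond to nitrogen now shows a much wider spread, with a 20-fold higher number from compound 1 to compound 4 (1.30 log units; beyond the scatter) and, against the methoxy-bearing ring, an 8.3-fold higher number from compound 3 to compound 4 (0.92 log units; beyond the scatter) as the two readable steps. Exchange at this position can therefore cost far more than the modest 2.4-fold higher number from compound 1 to compound 3 (0.38 log units; beyond the scatter) suggested, and in both numeric cases a substituted ring carries a higher number than the phenyl of compound 1, while compound 2 stays outside this pattern and any step involving it cannot be read, as it has no number. Nothing at hand explains the size of these steps.

The compounds shown do not separate the two hydroxy groups of compound 4, so it remains open whether the higher number follows from one of them, from both together, or from the ring pattern as a whole. A phenyl ring with a single hydroxy, or with an amine or a carboxylic acid in its place, would show whether the cost holds for other groups at this position.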